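Working notes on compound 4 in this cytotoxicity series

A few compounds are considered here, and "the series" means these few. Any claim that something is new, unique, unknown or untested is made for them only; others in the source may bear on it.

compound 1 `CCCOC(=O)c1c(C)coc1-c1ccc2c(CC)cccc2c1OC`: > 10 ug/mL
compound 2 `CCc1cccc2c(OC)c(-c3occ(C)c3C(=O)On3nnc4ccccc43)ccc12`: > 10 ug/mL
compound 3 `CCc1cccc2c(OC(C)=O)c(-c3occ(C)c3COC(C)=O)ccc12`: > 10 ug/mL

In a functional assay on KB cells (Homo sapiens) for cytotoxicity, read by MTT assay, with a stated time of 72 h (a lower number here means that less compound is needed, a higher number that more compound is needed for the effect), the value of compound 1 is a limit of the assay, not a number. The value of compound 2 is likewise a limit. Going by the values given here, the value of compound 3 is a limit as well, so every value so far sits at the limit of > 10 ug/mL in this assay, at which 3 of the 3 values shown sit. Among the compounds with values here, the only measured step, a step that the two limits leave unreadable from compound 1 to compound 2, is therefore unreadable. Compound 4 `CCc1cccc2c(OC)c(-c3occ(C)c3COC)ccc12` differs from compound 1 by methoxymethyl in place of propoxycarbonyl on an aromatic carbon. Within the data shown here, no measured step gives a size for this change, so for compound 4 the step that the limit leaves unreadable from compound 1 to compound 4 is expected to stay within the scatter and most likely to end again at a limit. Compound 4 is estimated at 15 ug/mL, range 5 ug/mL to 40 ug/mL.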

Compound 4, concentration for half-maximal effect: > 10 ug/mL
Compound 4: no number, only a limit (the forecaster's own chance of this, stated with the estimate: 75%); the middle value lies beyond the limit too.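

Going by these compounds alone, compound 1 and compound 4 each give a limit, not a number, so no step between them can be read: the limit of > 10 ug/mL in this assay, at which 4 of the 4 values shown sit. The compounds shown leave open how propoxycarbonyl and methoxymethyl compare in this assay.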